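The source may hold more compounds than are shown below. What is called first, only, known or untested is meant among the compounds shown, and "the series" means these compounds.

Working notes on the series. In a functional assay on HepG2 cells (Homo sapiens) for cytotoxicity, read by MTT assay, with a stated time of 48 h (a lower number here means a stronger inhibitor, a higher number a weaker inhibitor), compound 1 (`CC(=O)Oc1ccccc1C1CC(C)=NN1C(=O)CN1CCC(O)CC1`) gives 12300 nM and compound 2 (`O=C(CCl)N1N=C(c2cc3ccccc3oc2=O)CC1c1ccccc1`) gives 2980 nM, while compound 3 (`CNCC(=O)N1N=C(c2cc3ccccc3oc2=O)CC1c1ccccc1`) gives 24000 nM on the same read-out. Compound 3 and compound 1 lie within the scatter of each other, and the number of compound 2 is lower than both.

Compound 4 (`CC(C)(C)NCC(=O)N1N=C(c2cc3ccccc3oc2=O)CC1c1ccccc1`) has not yet been measured. It differs from compound 3 by tert-butyl in place of methyl on an amine nitrogen in one place: tert-butyl in place of methyl on an amine nitrogen.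

Among the compounds with values here, the one measured step that bears on this change, an 8.1-fold higher number from compound 2 to compound 3 (0.91 log units; beyond the scatter) with methylamino in place of chloro on a saturated chain carbon bound to a carbonyl carbon, was modest but beyond the scatter. That step altered the group on the chain carbon. Within the data shown here, no measured pair varies the group on the amine nitrogen, so the data give no direct size for this change, and the range has to stay wide. No step beyond the scatter is expected in this assay on this evidence. The expected step, a 1.2-fold lower number from compound 3 to compound 4 (0.08 log units; within the scatter) as estimated, stays within the scatter. Compound 4 is expected at an estimated 20000 nM with a range from 8000 nM to 50000 nM as the working window.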

Compound 4, half-maximal inhibitory concentration: 31400 nM
For compound 4 the middle estimate is 1.6-fold (0.20 log units) below the measured one; the measured number falls inside the stated range.
By their numbers in this assay, from the lowest: compound 2; then compounds 1, 3 and 4 (each within the scatter of the next, the first and the last beyond it).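

In this assay, within the data shown here, the group on the amine nitrogen is now varied directly for the first time: a 1.3-fold higher number from compound 3 to compound 4 (0.12 log units; within the scatter) is the result of tert-butyl in place of methyl, a change from 1 heavy atom to 4 at this place, and it leaves the two compounds indistinguishable on this read-out. The gap to the chloro compound is also seen with the larger group, since an 11-fold higher number from compound 2 to compound 4 (1.02 log units; beyond the scatter) accompanies (tert-butyl)amino in place of chloro on the saturated chain carbon bound to a carbonyl carbon, so among the compounds on this core the separation follows the presence of either amino group rather than the choice between methyl and tert-butyl. No measurement at hand accounts for these numbers.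

Going by these compounds, what remains open is whether a group of another kind on the amine nitrogen, such as a 2-hydroxyethyl chain or a cyclohexyl ring, or a morpholine in place of the secondary amine, would stay within the scatter of compound 3 on this read-out. On these data alone, it is equally open where a carboxylic acid on the chain carbon would fall relative to the chloro and amino compounds.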